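A Chloro Substituent Added to the Anilino Ring

The source may report more compounds than this note shows. Statements on the series, on what has been measured and on what is new or still open speak of the compounds shown alone.

Compound 1 `CCCCCCCCCCCCCCNc1nc(SCc2ccc(C(F)(F)F)cc2)nc2ccccc12` gives in a functional assay on MCF7 cells (Homo sapiens) for cytotoxicity, read by MTT assay, with a stated time of 72 h (a higher number here means a weaker inhibitor, a lower number a stronger inhibitor), only a limit, > 50000 nM.
Compound 2 `FC(F)(F)c1ccc(CSc2nc(N3CCCCC3)c3ccccc3n2)cc1` likewise gives only a limit, > 50000 nM.
Compound 3 `FC(F)(F)c1ccc(CSc2nc(Nc3ccccc3)c3ccccc3n2)cc1` gives 44000 nM.

Among the three values shown, compound 3 supplies the only actual number; the other two entries are limits of the measurement rather than numbers. Compound 4 `FC(F)(F)c1ccc(CSc2nc(Nc3cccc(Cl)c3)c3ccccc3n2)cc1` has yet to be measured. It differs from compound 3 in one place: chloro in place of hydrogen on an aromatic carbon. For the measured compounds named here, only one measured step exists, an at least 1.1-fold lower number from compound 2 to compound 3 (0.05 log units; that floor lies within the scatter), and its size can be stated only as a floor because of the limit of > 50000 nM in this assay, at which 2 of the 3 values shown sit. Going by the values given here, that step swaps the whole group attached to the core, whereas the change to compound 4 adds a single chloro to an anilino that is already in place, so no measured step speaks to it directly. Among the compounds with values here, with the one known number sitting close to the edge of what the measurement reports, a small shift in either direction, or none beyond the scatter, is what the data allow. The expected step is a 1.5-fold lower number from compound 3 to compound 4 (0.17 log units; within the scatter), a modest lowering. Compound 4 is therefore estimated at 30000 nM, with a range from 8000 nM to 50000 nM, and a real chance that only a limit is returned.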

Compound 4, half-maximal inhibitory concentration: 25100 nM
Compound 4: the middle estimate sits 1.2-fold (0.08 log units) above what was measured; low and high end bracket the measured number.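

For the compounds shown here, this is the first view of a substituent on the anilino ring itself, and in this assay the chloro of the 3-chlorophenyl group gives a 1.8-fold lower number from compound 3 to compound 4 (0.24 log units; within the scatter), so adding this one atom at this place produces no change that can be separated from ordinary repeat variation. Compound 4, like compound 3, still returns an actual number, so the anilino series now has two measured values that can be compared directly, and they agree within the scatter. Against the piperidin-1-yl compound the change reads an at least 1.9-fold lower number from compound 2 to compound 4 (0.29 log units; that floor lies within the scatter), and this can be stated only as a floor because compound 2 has no actual number to compare with: the limit of > 50000 nM in this assay, at which 2 of the 4 values shown sit.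

What the compounds shown leave open is whether any group on this ring can move the number beyond the scatter, for example a fluoro, a methoxy, a nitrile, an amine or a carboxylic acid on the same ring carbon. Also open, on these data alone, is whether a chloro on a different carbon of the ring would read any differently from the 3-chlorophenyl group.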